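From 3,4-difluorophenyl to 3-chlorophenyl on a shared core

A few compounds are considered here, and "the series" means these few. Any claim that something is new, unique, unknown or untested is made for them only; others in the source may bear on it.

In a functional assay on OVCAR-4 cells (Homo sapiens) for inhibition, read by sulforhodamine B assay, with a stated time of 48 h (a lower number here means a stronger inhibitor of growth, a higher number a weaker inhibitor of growth), compound 1 `CN1CCN(CCCOc2cccc3nc(Nc4ccc(Cl)c(F)c4)ccc23)CC1` gives 3130 nM. Compound 2 `CC(C)c1ccc(Nc2ccc3c(OCCCN4CCN(C)CC4)cccc3n2)cc1` gives 13900 nM, and the gap between these two is a 4.4-fold higher number from compound 1 to compound 2 (0.65 log units; beyond the scatter). Compound 3 `CN1CCN(CCCOc2cccc3nc(Nc4ccc(F)c(F)c4)ccc23)CC1` gives 6420 nM, the middle of the three numbers.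

Compound 4 `CN1CCN(CCCOc2cccc3nc(Nc4cccc(Cl)c4)ccc23)CC1` has 3-chlorophenyl in place of 3,4-difluorophenyl on a nitrogen on an aromatic ring. The closest measured comparison is a 2.1-fold higher number from compound 1 to compound 3 (0.31 log units; beyond the scatter), where fluoro takes the place of chloro on an aromatic carbon. Read in reverse, this suggests that going from fluoro to chloro could lower the number. The step of a 2.2-fold lower number from compound 2 to compound 3 (0.34 log units; beyond the scatter) shows that the group on this nitrogen matters in this assay, but it involves a very different group. Going by the values given here, no measured pair shows what removing a fluoro alone does. A small step to a lower number is therefore expected in this assay, possibly none beyond the scatter. The estimated step is a 1.4-fold lower number from compound 3 to compound 4 (0.15 log units; within the scatter). For compound 4, the estimated value is 4500 nM, with an expected range of 2000 nM to 10000 nM.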

Compound 4, concentration for 50% growth inhibition: 1940 nM
Compound 4: middle estimate off by 2.3-fold (0.37 log units), on the high side, outside the stated range (below it).
By their numbers in this assay, from the lowest: compounds 4 and 1 (each within the scatter of the next); then compound 3; then compound 2.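

In this assay, going by these compounds alone, the change from 3,4-difluorophenyl to 3-chlorophenyl gives a 3.3-fold lower number from compound 3 to compound 4 (0.52 log units; beyond the scatter) and is the first sign that a ring carrying chloro and no fluoro can do well on this nitrogen. Set against 4-isopropylphenyl, the same group gives a 7.2-fold lower number from compound 2 to compound 4 (0.86 log units; beyond the scatter) and this is the widest step among the four compounds. The step of a 1.6-fold lower number from compound 1 to compound 4 (0.21 log units; within the scatter) lies within the scatter, so 3-chlorophenyl and 4-chloro-3-fluorophenyl cannot be told apart here, and the two chloro-bearing groups share the low end of the series.

Still open, going by these compounds, is how 3-bromophenyl, 3-methoxyphenyl or plain phenyl on this nitrogen would compare with 3-chlorophenyl. Nothing available here explains why these groups rank as they do.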